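Series notes: methoxy removal from compound 2

The source may report more compounds than this note shows. Statements on the series, on what has been measured and on what is new or still open speak of the compounds shown alone.

Of the compounds shown here, three with the shared core have been measured in a functional assay on UACC-257 cells (Homo sapiens) for cytotoxicity, read by sulforhodamine B assay, with a stated time of 48 h, tested at 1 uM; a higher number here means a weaker effect of the compound at the concentration tested, a lower number a stronger effect. Compound 1 `COc1ccc(-c2cc(/C=C/C(=O)c3ccc(N)cc3)[nH]n2)cc1` gives 90%, compound 2 `COc1cc(-c2cc(/C=C/C(=O)c3ccc(N)cc3)[nH]n2)cc(OC)c1OC` gives 91% and compound 3 `COc1ccc(C(=O)/C=C/c2cc(-c3cc(OC)c(OC)c(OC)c3)n[nH]2)cc1` gives 87%. All three numbers lie within the usual scatter of one another, so compound 2 cannot be set apart from the other two. For the measured compounds named here, the one measured step, a number 4 percentage points lower from compound 2 to compound 3 (within the scatter), concerns methoxy in place of amino on an aromatic carbon and also stays within the scatter. Compound 4 `COc1ccc(-c2cc(/C=C/C(=O)c3ccc(N)cc3)[nH]n2)cc1OC` differs from compound 2 by hydrogen in place of methoxy on an aromatic carbon. Going by the values given here, no measured step removes a methoxy, and the step that exists touches a different group, so nothing beyond the scatter is expected in this assay. Compound 4 is estimated at 90%, within 78% to 98%. This amounts to an expected a number 1 percentage points lower from compound 2 to compound 4 (within the scatter), within the scatter.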

Compound 4, a percentage reported as activity, at one concentration (the size of the read-out at that concentration, not a potency): 96%
Compound 4: the middle estimate sits 6 percentage points below what was measured; the range from low to high includes it.
By their numbers in this assay, from the lowest: compounds 3, 1, 2 and 4 (each within the scatter of the next).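

In this assay, replacing methoxy with hydrogen on this aromatic carbon, ortho to a methoxy group and meta to a large group, gives a step within the scatter (a number 5 percentage points higher from compound 2 to compound 4 (within the scatter)). Approaching the same compound from the other side, with methoxy in place of hydrogen, also stays within the scatter (a number 6 percentage points higher from compound 1 to compound 4 (within the scatter)). Methoxy and hydrogen at this place therefore cannot be told apart in this read-out, and nothing measured offers an explanation. Still open, going by these compounds, is whether a hydroxyl or a fluorine here would produce a step beyond the scatter.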